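Swapping the distal aryl group for cyclohexyl

The source may hold more compounds than are shown below. What is called first, only, known or untested is meant among the compounds shown, and "the series" means these compounds.

Measured so far, in a physicochemical assay for acid dissociation:
compound 1 `Cc1cc(C)cc(Cc2ccc3c(NCCCNCc4ccco4)ccnc3c2)c1` gives 9.47
compound 2 `COc1ccc(-c2ccc3c(NCCCNCc4ccco4)ccnc3c2)cc1` gives 9.47
compound 3 `COc1ccc(Oc2ccc3c(NCCCNCc4ccco4)ccnc3c2)cc1` gives 9.28

Compound 3 holds the lowest of the three numbers, yet its gaps to the others are small: a number 0.19 log units lower from compound 1 to compound 3 (within the scatter) and a number 0.19 log units lower from compound 2 to compound 3 (within the scatter), both within the scatter, as is no change at the digits printed from compound 1 to compound 2 (within the scatter). Compound 4 `c1coc(CNCCCNc2ccnc3cc(C4CCCCC4)ccc23)c1` is not yet measured. It differs from compound 3 at one spot: cyclohexyl in place of 4-methoxyphenoxy on an aromatic carbon. Going by the values given here, every step so far has changed only this remote group, and none moved this assay beyond the scatter, so a further change there is expected to leave it flat. The step of a number 0.12 log units higher from compound 3 to compound 4 (within the scatter) is therefore expected to be negligible. Compound 4 is estimated at 9.4, between 9.1 and 9.7.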

Compound 4, acid dissociation constant: 9.47
Compound 4: middle estimate off by 0.07 log units, on the low side; the range from low to high includes it.
By their numbers in this assay, from the lowest: compounds 3, 1, 2 and 4 (each within the scatter of the next).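

In this assay, replacing the earlier aromatic-ring groups with cyclohexyl, a non-aromatic ring without hydrogen-bond acceptors, gives a number 0.19 log units higher from compound 3 to compound 4 (within the scatter), no change at the digits printed from compound 2 to compound 4 (within the scatter) and no change at the digits printed from compound 1 to compound 4 (within the scatter). Across these four compounds, then, an aromatic ring in this group is not needed to keep the number within the scatter. No supporting data offer a reason for this flatness. Going by these compounds, whether an amine or a carboxylic acid on this aromatic carbon would also leave the number flat stays open, as does the effect of any change elsewhere in the shared core.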